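Swapping a carbamate for a bromopyridinyl ether on the side chain

The source may hold more compounds than are shown below. What is called first, only, known or untested is meant among the compounds shown, and "the series" means these compounds.

Among the measured compounds shown here, in an assay on frontal cortex for displacement of a labelled ligand from corticotropin-releasing factor receptor 1 (Rattus norvegicus), with a stated time of 2 h (on this read-out lower numbers stand for stronger inhibition and higher numbers for weaker inhibition), compound 1 `COc1nc(C)c(Nc2nc(Cl)cn([C@H](COC(=O)Nc3ccc(Cl)cc3)C3CC3)c2=O)cc1C` gives 1.6 nM, while compound 2 `CCCNC(=O)OC[C@H](C1CC1)n1cc(Cl)nc(Nc2cc(C)c(OC)nc2C)c1=O` gives 10 nM, the higher of the two numbers; the only measured step, a 6.3-fold higher number from compound 1 to compound 2 (0.80 log units; beyond the scatter), replaced an aromatic group with a propyl chain. Compound 3 `COc1nc(C)c(Nc2nc(Cl)cn([C@H](COc3cc(Br)ccn3)C3CC3)c2=O)cc1C` differs from compound 2 by 4-bromopyridin-2-yl in place of propylcarbamoyl on an oxygen on a saturated carbon. For the measured compounds named here, no measured step covers this exchange, so the expectation leans on the step from compound 1 to compound 2 alone, where an aromatic group went with the lower number. For compound 3 an improvement is expected, about a 3.3-fold lower number from compound 2 to compound 3 (0.52 log units; beyond the scatter), giving an estimated 3 nM with a range from 0.8 nM to 15 nM.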

Compound 3, half-maximal inhibitory concentration: 1.5 nM
Compound 3: middle estimate off by 2.0-fold (0.30 log units), on the high side, within the range that was stated.
By their numbers in this assay, from the lowest: compounds 3 and 1 (each within the scatter of the next); then compound 2.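

On the oxygen of the side chain, 4-bromopyridin-2-yl in place of propylcarbamoyl gives a clear gain (a 6.7-fold lower number from compound 2 to compound 3 (0.82 log units; beyond the scatter)). Set against (4-chlorophenyl)carbamoyl, the same ring gives no difference beyond the scatter (a 1.1-fold lower number from compound 1 to compound 3 (0.03 log units; within the scatter)), so an aromatic ring placed directly on this oxygen reads like one carried through a carbamate. The hydrogen-bond donor of the carbamate is therefore not required for a low number here, though no measurement available explains this result.

On these data alone, whether the bromine itself matters stays open, as does how an unsubstituted pyridin-2-yl, a plain phenyl or a saturated amine on this oxygen would read.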